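Thioether aryl exchange on the shared core

The compounds below may be only part of what the source reports. "The series", "measured", "known", "first", "only" and "open" are said of these compounds alone.

Compound 1 `Cc1cc(Nc2cc(-c3ccccc3)[nH]n2)n2nc(SCc3ccc(F)cc3)nc2n1` serves as the reference point. For the measured compounds named here, in a functional assay on MGC-803 cells (Homo sapiens) for inhibition, read by MTT assay, with a stated time of 72 h (on this read-out lower numbers stand for stronger inhibition and higher numbers for weaker inhibition), compound 1 gives 3270 nM, the lowest of the two numbers measured so far. Compound 2 `Cc1cc(Nc2cc(-c3ccccc3)[nH]n2)n2nc(SCc3ccc([N+](=O)[O-])cc3)nc2n1` carries nitro in place of fluoro on an aromatic carbon; in this assay compound 2 gives 4250 nM, and the step of a 1.3-fold higher number from compound 1 to compound 2 (0.11 log units; within the scatter) stays within the scatter, so the two values cannot be ordered. Compound 3 `Cc1cc(Nc2cc(-c3ccccc3)[nH]n2)n2nc(SCc3cccc4ccccc34)nc2n1` has not yet been measured. Its difference from compound 1 is naphthalen-1-yl in place of 4-fluorophenyl on a saturated chain carbon bound to a sulfur. Going by the values given here, no measured step bears directly on this change: the only recorded step, a 1.3-fold higher number from compound 1 to compound 2 (0.11 log units; within the scatter), exchanges a substituent on the same ring rather than the ring itself, and it was flat. Among the compounds with values here, with no guiding step, the step of a 1.1-fold lower number from compound 1 to compound 3 (0.04 log units; within the scatter) is expected to fall within the scatter. Compound 3 is therefore estimated at 3000 nM. The expected range runs from 1000 nM to 9000 nM. The range is kept wide, as nothing measured tests an exchange of this kind.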

Compound 3, half-maximal inhibitory concentration: 3120 nM
Compound 3: the middle estimate sits 1.0-fold (0.02 log units) below what was measured, within the range that was stated.
By their numbers in this assay, from the lowest: compounds 3, 1 and 2 (each within the scatter of the next).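

At the saturated chain carbon bound to a sulfur, exchanging the whole aryl group rather than a substituent on it now has a reading in this assay: the step to naphthalen-1-yl gives a 1.0-fold lower number from compound 1 to compound 3 (0.02 log units; within the scatter) and, from the nitro analogue, a 1.4-fold lower number from compound 2 to compound 3 (0.13 log units; within the scatter), so neither change can be ordered. Going from 7 to 10 heavy atoms, and from one six-membered aromatic ring to 2, thus leaves the number within the scatter for the three aryl groups shown. Nothing available bears on why these values stay together.

Still open, as far as these compounds go, is whether this place accepts anything other than an aryl group, such as an amine, a carboxylic acid or a longer alkyl chain on the carbon bound to the sulfur. Also open, from the compounds shown here alone, is whether the same flat picture would hold on a different core, since all three compounds share one.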